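From a Branched Group to a Phenethyl Chain

The source may report more compounds than this note shows. Statements on the series, on what has been measured and on what is new or still open speak of the compounds shown alone.

Among the compounds with values here, the three compounds measured so far share one core and differ only in the group on an aromatic carbon of a five-membered aromatic ring with 3 nitrogen. In a functional assay on HeLa cells (Homo sapiens) for inhibition, read by MTT assay, with a stated time of 72 h (on this read-out lower numbers stand for stronger inhibition and higher numbers for weaker inhibition), compound 1 `O=c1cc(Cn2cc(C3CC3)nn2)c2ccc(O)cc2o1` gives > 100000 nM, which is a limit of the assay and not a number. Compound 2 `CC(O)c1cn(Cc2cc(=O)oc3cc(O)ccc23)nn1` likewise gives only a limit, > 100000 nM. Within the data shown here, compound 3 `CC(C)(C)c1cn(Cc2cc(=O)oc3cc(O)ccc23)nn1` gives 81100 nM, the only real number among the three values shown in this assay. Two measured steps lead to compound 3: an at least 1.2-fold lower number from compound 1 to compound 3 (0.09 log units; that floor lies within the scatter) and an at least 1.2-fold lower number from compound 2 to compound 3 (0.09 log units; that floor lies within the scatter). Both start from the limit of > 100000 nM in this assay, at which 2 of the 3 values shown sit, so their true size cannot be read; they show only that tert-butyl yields a readable value where cyclopropyl and 1-hydroxyethyl do not.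

Compound 4 `O=c1cc(Cn2cc(CCc3ccccc3)nn2)c2ccc(O)cc2o1` is not yet measured. It differs from compound 3 in one place: phenethyl in place of tert-butyl on an aromatic carbon. The two steps toward compound 3 bear on this change only loosely, since they replace tert-butyl in the other direction and their floors lie within the scatter. Among the measured compounds shown here, no measured step therefore points to a clear direction, and a step within the scatter, or a modest one either way, is the most that can be expected. For compound 4 the expected value in this assay is estimated at 60000 nM, within a range from 15000 nM to 150000 nM. This estimate corresponds to an expected step of a 1.4-fold lower number from compound 3 to compound 4 (0.13 log units; within the scatter).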

Compound 4, half-maximal inhibitory concentration: 35100 nM
For compound 4 the middle estimate is 1.7-fold (0.23 log units) above the measured one, within the range that was stated.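

In this assay, phenethyl in place of tert-butyl on this aromatic carbon gives a 2.3-fold lower number from compound 3 to compound 4 (0.36 log units; beyond the scatter). Within the data shown here, this is the first step at this position with a real number at both ends, so its size can be read, and a larger group carrying a six-membered aromatic ring of carbon only, with 8 heavy atoms where tert-butyl has 4, brings a lower number, not a higher one. The other two steps, an at least 2.8-fold lower number from compound 2 to compound 4 (0.45 log units; beyond the scatter) and an at least 2.8-fold lower number from compound 1 to compound 4 (0.45 log units; beyond the scatter), give only floors, since each starts from a value that is a limit and not a number: the limit of > 100000 nM in this assay, at which 2 of the 4 values shown sit.

On these data alone, whether the step belongs to the aromatic ring of phenethyl or simply to the length of the chain stays open, and a plain butyl chain or a benzyl group on this carbon would help to separate the two. Also open, as far as these compounds go, is how the number would move with an amine or a carboxylic acid on the aromatic ring of phenethyl, or with a chain longer than the two carbons that link that ring here.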